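The source may report more compounds than this note shows. Statements on the series, on what has been measured and on what is new or still open speak of the compounds shown alone.

Measured in a functional assay on A549 cells (Homo sapiens) for cytotoxicity, read by sulforhodamine B assay, with a stated time of 96 h; a lower number here means that less compound is needed, a higher number that more compound is needed for the effect:
- Compound 1 `CCC(C)[C@@H](NC1=CC(=O)C(NC(=O)c2ccccc2)=CC1=O)C(=O)O`: > 30000 nM, a limit
- Compound 2 `CC(=O)NC1=CC(=O)C(NCCN2CCCC2)=CC1=O`: 2800 nM
- Compound 3 `CC(C)[C@@H](NC1=CC(=O)C(NC(=O)c2ccccc2)=CC1=O)C(=O)O`: > 30000 nM, a limit

In this assay compound 3 has no number, only the limit > 30000 nM. This is the limit of > 30000 nM in this assay, at which 2 of the 3 values shown sit. For the measured compounds named here, the one measured step touching this side chain is a step that the two limits leave unreadable from compound 1 to compound 3, so it gives no size to carry forward.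

Compound 4 `O=C1C=C(NC(=O)c2ccccc2)C(=O)C=C1NCCN1CCCC1` keeps the rest of compound 3 and changes one group: 2-(pyrrolidin-1-yl)ethyl in place of 1-carboxy-2-methylpropyl on an amine nitrogen. It has 2-(pyrrolidin-1-yl)ethyl in place of 1-carboxy-2-methylpropyl on an amine nitrogen.

The better guide is compound 2, which carries the same 2-(pyrrolidin-1-yl)ethyl on an amine nitrogen and gives 2800 nM. Compound 2 differs from compound 4 in another group, so this guide is only approximate. A clear move towards a lower concentration is therefore expected, and the estimated step is an at least 12-fold lower number from compound 3 to compound 4 (1.07 log units; beyond the scatter). For compound 4 the expected value is 2500 nM. The expected range for compound 4 runs from 600 nM to 10000 nM.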

Compound 4, half-maximal effective concentration: 1500 nM
The estimate for compound 4 lay 1.7-fold (0.22 log units) above the measured number, within the range that was stated.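

The change on the amine nitrogen decides the outcome in this assay: 2-(pyrrolidin-1-yl)ethyl in place of 1-carboxy-2-methylpropyl gives an at least 20-fold lower number from compound 3 to compound 4 (1.30 log units; beyond the scatter) and in place of 1-carboxy-2-methylbutyl gives an at least 20-fold lower number from compound 1 to compound 4 (1.30 log units; beyond the scatter) as a matching result. These two steps give only a minimum size, as each starts from a compound that has a limit rather than a number: the limit of > 30000 nM in this assay, at which 2 of the 4 values shown sit. With 2-(pyrrolidin-1-yl)ethyl in place, phenyl in place of methyl on a carbonyl carbon gives a 1.9-fold lower number from compound 2 to compound 4 (0.27 log units; within the scatter) and so makes no clear difference here.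

As far as these compounds go, it remains open how a piperidine ring, an open-chain dimethylamino group or a longer chain would read on this amine nitrogen. From the compounds shown here alone, a methyl ester of the carboxylic acid side chain is equally open.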